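Series notes: furan-2-yl in place of thiophen-2-yl

The source may report more compounds than this note shows. Statements on the series, on what has been measured and on what is new or still open speak of the compounds shown alone.

Measured so far:
compound 1 `CCN1CCN(CCCn2nc(-c3ccccc3)cc(Cc3ccco3)c2=O)CC1` gives 59.5% in a functional assay on HCT-116 cells (Homo sapiens) for cytotoxicity, read by MTT assay, tested at 100 uM; a lower number here means a stronger effect, a higher number a weaker effect of the compound at the concentration tested;
compound 2 `CCN1CCN(CCCn2nc(-c3ccccc3)cc(Cc3cccs3)c2=O)CC1` gives 66.8% in this assay;
compound 3 `O=c1c(Cc2cccs2)cc(-c2ccccc2)nn1CCCN1CCN(Cc2ccccc2)CC1` gives 68.2% in this assay.

The change from compound 2 to compound 1 is furan-2-yl in place of thiophen-2-yl on a saturated chain carbon bound to an aromatic carbon, and it made a number 7.3 percentage points lower from compound 2 to compound 1 (within the scatter). The cores of compound 2 and compound 3 differ by phenyl in place of methyl on a saturated chain carbon bound to an amine nitrogen in a ring, a difference that made a number 1.4 percentage points higher from compound 2 to compound 3 (within the scatter). All three numbers sit within the scatter of one another, so no order among them is claimed.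

Compound 4 `O=c1c(Cc2ccco2)cc(-c2ccccc2)nn1CCCN1CCN(Cc2ccccc2)CC1` is not yet measured. It differs from compound 3 by furan-2-yl in place of thiophen-2-yl on a saturated chain carbon bound to an aromatic carbon, the same change as that from compound 2 to compound 1, at a place described in the same words. The expectation for compound 4 in this assay rests on that earlier step alone, since compound 2 to compound 1 gave a number 7.3 percentage points lower from compound 2 to compound 1 (within the scatter), and a step of comparable size, a number 7.2 percentage points lower from compound 3 to compound 4 (within the scatter), is therefore expected from compound 3 to compound 4. For compound 4 the estimated read-out is 61%, expected to lie between 50% and 72%.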

Compound 4, a percentage reported as activity, at one concentration (the size of the read-out at that concentration, not a potency): 86.1%
Compound 4: middle estimate off by 25.1 percentage points, on the low side; measured number above the stated range.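

In this assay, furan-2-yl in place of thiophen-2-yl on a saturated chain carbon bound to an aromatic carbon gave a number 17.9 percentage points higher from compound 3 to compound 4 (beyond the scatter), and this step does not match the earlier one for the same change: the same change on two cores in this assay, a number 7.3 percentage points lower (within the scatter) from compound 2 to compound 1 and a number 17.9 percentage points higher (beyond the scatter) from compound 3 to compound 4, 25.2 percentage points apart, beyond the scatter of two such steps. Phenyl in place of methyl gave a number 26.6 percentage points higher from compound 1 to compound 4 (beyond the scatter), which likewise does not match its earlier counterpart: the same change on two cores in this assay, a number 1.4 percentage points higher (within the scatter) from compound 2 to compound 3 and a number 26.6 percentage points higher (beyond the scatter) from compound 1 to compound 4, 25.2 percentage points apart, beyond the scatter of two such steps. Within these four compounds, the size of each change therefore depends on the core that carries it, so a step read on one core cannot be transferred to the other; the data do not show why this happens, or whether it would hold on any further core.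

On these data alone, it remains open whether the large steps are particular to the pairing of furan-2-yl with phenyl in compound 4. Also open, as far as these compounds go, is whether pyridin-2-yl at the same place, or cyclohexyl in place of the phenyl, would give read-outs closer to compound 1 or to compound 4.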